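Amine variation on the shared core against the B1 receptor

This account rests on a few compounds, and the source may have more. Where it says the series, first, only, none or still open, it means among the compounds named here.

Three compounds share one core and differ only in the amine carried on the saturated chain carbon bound to an aromatic carbon. Compound 1 `CC(C)(C)CNCc1ccc2c(c1)CCC[C@H]2NC(=O)C[C@@H]1CCCCN1S(=O)(=O)c1cccc(C(F)(F)F)c1` carries neopentylamino there, and in an assay on isolated protein for inhibition of B1 bradykinin receptor (Homo sapiens) (on this read-out lower numbers stand for stronger inhibition and higher numbers for weaker inhibition), compound 1 gives 59 nM. Compound 2 `O=C(C[C@@H]1CCCCN1S(=O)(=O)c1cccc(C(F)(F)F)c1)N[C@@H]1CCCc2cc(CNC3CC3)ccc21` carries cyclopropylamino, and compound 2 gives 48 nM. Compound 3 `CN(C)Cc1ccc2c(c1)CCC[C@H]2NC(=O)C[C@@H]1CCCCN1S(=O)(=O)c1cccc(C(F)(F)F)c1` carries dimethylamino, and compound 3 gives 62 nM. The steps between them are all small: a 1.2-fold lower number from compound 1 to compound 2 (0.09 log units; within the scatter), a 1.1-fold higher number from compound 1 to compound 3 (0.02 log units; within the scatter), and a 1.3-fold higher number from compound 2 to compound 3 (0.11 log units; within the scatter). Compound 3 thus holds the highest of the three numbers, but its gaps to compound 1 and to compound 2 are within the scatter, so the three stand level.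

Compound 4 `O=C(C[C@@H]1CCCCN1S(=O)(=O)c1cccc(C(F)(F)F)c1)N[C@@H]1CCCc2cc(CN3CCC3)ccc21` is the next member: azetidin-1-yl in place of dimethylamino on a saturated chain carbon bound to an aromatic carbon. Among the measured compounds shown here, no measured step exchanges one tertiary amine for another; the steps that bear on it are those from compound 1 and compound 2 to compound 3, where a secondary amine became dimethylamino with no change beyond the scatter. Since every amine change so far has left the number where it was, the step of a 1.1-fold lower number from compound 3 to compound 4 (0.05 log units; within the scatter) is expected to stay within the scatter. Compound 4 is estimated at 55 nM, with a range from 25 nM to 120 nM.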

Compound 4, half-maximal inhibitory concentration: 1100 nM
Compound 4: middle estimate off by 20-fold (1.30 log units), on the low side; measured number above the stated range.
By their numbers in this assay, from the lowest: compounds 2, 1 and 3 (each within the scatter of the next); then compound 4.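

In this assay this position proves sensitive to the amine after all: the step of an 18-fold higher number from compound 3 to compound 4 (1.25 log units; beyond the scatter) is large, although the change only takes dimethylamino to azetidin-1-yl, 4 heavy atoms in place of 3, with the same hydrogen-bond donor and acceptor counts and no net charge on either group. The two secondary amines give the same picture, with a 23-fold higher number from compound 2 to compound 4 (1.36 log units; beyond the scatter) and a 19-fold higher number from compound 1 to compound 4 (1.27 log units; beyond the scatter) also large, so the level numbers seen across neopentylamino, cyclopropylamino and dimethylamino do not extend to azetidin-1-yl, the only one of the four amines with its nitrogen inside a ring. Nothing at hand accounts for this drop in the series.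

As far as these compounds go, whether the drop belongs to the four-membered ring in particular or to any ring that holds this nitrogen stays open, and pyrrolidin-1-yl or piperidin-1-yl on the same saturated chain carbon would separate the two readings. Diethylamino in the same place would show whether open-chain tertiary amines stay level with dimethylamino.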